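The source may report more compounds than this note shows. Statements on the series, on what has been measured and on what is new or still open speak of the compounds shown alone.

The measured compounds are compound 1 `COc1cc(-c2cc(/C=C/C(=O)c3ccc(N)cc3)[nH]n2)cc(OC)c1OC` with 105%, compound 2 `COc1ccc(C(=O)/C=C/c2cc(-c3cc(OC)c(OC)c(OC)c3)n[nH]2)cc1OC` with 94% and compound 3 `COc1ccc(-c2cc(/C=C/C(=O)c3ccc(N)cc3)[nH]n2)cc1OC` with 103%, all in a functional assay on NCI-H23 cells (Homo sapiens) for cytotoxicity, read by sulforhodamine B assay, with a stated time of 48 h, tested at 0.1 uM; a lower number here means a stronger effect, a higher number a weaker effect of the compound at the concentration tested.

Compound 3 and compound 1 share a core and differ in one place: methoxy in place of hydrogen on an aromatic carbon. In this assay this change gave a number 2 percentage points higher from compound 3 to compound 1 (within the scatter). Compound 1 and compound 2 differ in another way, a number 11 percentage points lower from compound 1 to compound 2 (beyond the scatter), and compound 2 holds the lowest of the three numbers, though its distance to compound 3 is within the scatter. The difference between the core of compound 2 and the core of compound 3 is not broken down here.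

Compound 4 `COc1cc(C(=O)/C=C/c2cc(-c3cc(OC)c(OC)c(OC)c3)n[nH]2)cc(OC)c1OC` has not yet been measured in this assay. It is related to compound 2 exactly as compound 1 is to compound 3: methoxy in place of hydrogen on an aromatic carbon. The surroundings of the entering group are described in the same words in both cases, so this is the same change made a second time, now on the core of compound 2.

Because a number 2 percentage points higher from compound 3 to compound 1 (within the scatter) was a step within the scatter, the expectation for compound 4 is a similarly small step, estimated as a number 2 percentage points higher from compound 2 to compound 4 (within the scatter), which rests only on that single earlier pair and on the value of compound 2, 94%. Compound 4 is therefore expected to give about 96% in this assay, with a likely range from 86% to 106%.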

Compound 4, a percentage reported as activity, at one concentration (the size of the read-out at that concentration, not a potency): 101%
The estimate for compound 4 lay 5 percentage points below the measured number; the range from low to high includes it.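

In this assay, methoxy in place of hydrogen on an aromatic carbon, here ortho to one methoxy group and meta to another, gave a number 7 percentage points higher from compound 2 to compound 4 (within the scatter). Set beside the earlier case, the change reads the same on the two cores, as far as this read-out can tell: the same change on two cores in this assay, a number 2 percentage points higher (within the scatter) from compound 3 to compound 1 and a number 7 percentage points higher (within the scatter) from compound 2 to compound 4, 5 percentage points apart, within the scatter of two such steps. For the compounds shown here, this shows only that the change left the number within the scatter on both cores, so the pairs give no sign of a real effect on either core and offer no measurable effect to carry from one to the other, and since all of this rests on two pairs read at a single concentration, it says nothing about potency or about other cores.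

The compounds shown leave open whether a different group at this place, such as an amine, a hydroxyl or a longer chain like ethoxy, would move the number beyond the scatter. They also leave open whether the methoxy change would still read the same on a core that gives a clearly stronger effect in this assay, as none of the four pairs with such a core here.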